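This account rests on a few compounds, and the source may have more. Where it says the series, first, only, none or still open, it means among the compounds named here.

Compound 2 `O=Cc1ccc(-c2cn3ccnc3c(-c3ccc4ncn(C5CCCCC5)c4c3)n2)cc1` gives 45.5% in a functional assay on Hs-578T cells (Homo sapiens) for inhibition, read by sulforhodamine B assay, with a stated time of 48 h, tested at 10 uM (on this read-out lower numbers stand for less inhibition and higher numbers for more inhibition at the one concentration tested (going by the name of the read-out)), the higher of the two numbers in hand, while compound 1 `Brc1cn2ccnc2c(-c2ccc3ncn(C4CCCCC4)c3c2)n1` gives 16.1%. Within the data shown here, the single measured step, a number 29.4 percentage points higher from compound 1 to compound 2 (beyond the scatter), concerns the same place on the shared core but exchanges a different pair of groups. Compound 3 `c1ccc2c(-c3cn4ccnc4c(-c4ccc5ncn(C6CCCCC6)c5c4)n3)cccc2c1` differs from compound 2 by naphthalen-1-yl in place of 4-formylphenyl on an aromatic carbon. Among the measured compounds shown here, no measured step exchanges one aryl group for another, so the direction is open. A step of a number 5.5 percentage points lower from compound 2 to compound 3 (within the scatter) is expected, within the scatter. Compound 3 is therefore estimated at 40%, with a range from 15% to 65%.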

Compound 3, a percentage reported as inhibition, at one concentration (the size of the read-out at that concentration, not a potency): 3.62%
For compound 3 the middle estimate is 36.4 percentage points above the measured one, and the stated range ends above it.
By their numbers in this assay, from the lowest: compound 3; then compound 1; then compound 2.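

At this position the identity of the aryl group decides the read-out: naphthalen-1-yl in place of 4-formylphenyl gives a number 41.9 percentage points lower from compound 2 to compound 3 (beyond the scatter) in this assay and shows that an added aryl group does not by itself raise the number. Naphthalen-1-yl in place of bromo gives a number 12.5 percentage points lower from compound 1 to compound 3 (beyond the scatter) and so places the two aryl groups on opposite sides of bromo. Nothing in hand accounts for the gap between these aryl groups.

On these data alone, whether the formyl group or the phenyl ring carries the rise stays open. Plain phenyl, or a phenyl ring bearing an amine or a carboxylic acid, would separate the two.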